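Two methoxy groups on the pendant phenyl: an expectation

The source may report more compounds than this note shows. Statements on the series, on what has been measured and on what is new or still open speak of the compounds shown alone.

Measured compounds:
compound 1, `O=C(CCCCC1CCSS1)NCc1cn(CCCCCOc2ccc3ccc(=O)oc3c2)nn1`, 78.5%
compound 2, `CCOC(=O)c1cc2ccc(OCCCCCn3cc(CNC(=O)CCCCC4CCSS4)nn3)cc2oc1=O`, 39.5%
compound 3, `O=C(CCCCC1CCSS1)NCc1cn(CCCCCOc2ccc3cc(-c4ccccc4)c(=O)oc3c2)nn1`, 20.7%

In a functional assay on PC-12 cells (Rattus norvegicus) for cytotoxicity, read by MTT assay, with stated times of 3 h and 2 h, tested at 20 uM (on this read-out higher numbers stand for a stronger effect at the one concentration tested and lower numbers for a weaker effect), compound 3 stands lowest of the three, with the step of a number 18.8 percentage points lower from compound 2 to compound 3 (beyond the scatter) and the step of a number 57.8 percentage points lower from compound 1 to compound 3 (beyond the scatter) both beyond the scatter. Compound 4 is `COc1ccc(-c2cc3ccc(OCCCCCn4cc(CNC(=O)CCCCC5CCSS5)nn4)cc3oc2=O)cc1OC`, which differs from compound 3 by 3,4-dimethoxyphenyl in place of phenyl on an aromatic carbon. Among the measured compounds shown here, no measured step exchanges one phenyl for another; the steps that bear on this position, a number 57.8 percentage points lower from compound 1 to compound 3 (beyond the scatter) and a number 18.8 percentage points lower from compound 2 to compound 3 (beyond the scatter), show that enlarging the group here has so far lowered the read-out, but they give no direct guide to the two methoxy groups. Compound 3 already lies near the low end of the scale, so an expected step of a number 2.7 percentage points lower from compound 3 to compound 4 (within the scatter) in this assay, within the scatter, seems most likely. Compound 4 is therefore estimated at 18%, between 5% and 35%.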

Compound 4, a percentage reported as activity, at one concentration (the size of the read-out at that concentration, not a potency): 51.9%
Beside the measured number, compound 4's estimate is 33.9 percentage points below it; measured number above the stated range.
By their numbers in this assay, from the lowest: compound 3; then compound 2; then compound 4; then compound 1.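

In this assay, the unsubstituted phenyl proves not to set a floor for aryl groups at this position: adding two methoxy groups to it gives a number 31.2 percentage points higher from compound 3 to compound 4 (beyond the scatter), so what the pendant ring carries matters, and enlargement here does not always lower the read-out. The 3,4-dimethoxyphenyl group also outranks ethoxycarbonyl, with a number 12.4 percentage points higher from compound 2 to compound 4 (beyond the scatter), while hydrogen stays ahead of it, with a number 26.6 percentage points lower from compound 1 to compound 4 (beyond the scatter). No evidence is at hand to explain these differences. As far as these compounds go, whether a single methoxy group would suffice remains open, as does what a hydroxy group or an amine on the pendant phenyl would do.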